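The compounds below may be only part of what the source reports. "The series", "measured", "known", "first", "only" and "open" are said of these compounds alone.

Measured so far:
- compound 1, `O=C1CCCN1CCCSc1nc2cc(Cl)ccc2o1`: 4.8 mL/min/g
- compound 2, `O=C(CCCc1nc2cc(Cl)ccc2o1)N1CCCC1`: 1.4 mL/min/g
- compound 3, `CN1CCN(C(=O)CCSc2nc3cc(Cl)ccc3o2)CC1`: 1.5 mL/min/g

In an ADME assay on microsomes from liver (Homo sapiens) for metabolic stability, read by LC-MS, using NADPH, with a stated time of 45 min, tested at 0.5 uM (on this read-out lower numbers stand for slow clearance and higher numbers for fast clearance), compound 1 gives 4.8 mL/min/g, the highest of the three numbers. The nearest of the others is compound 3, which gives 1.5 mL/min/g, a gap beyond the scatter, and the furthest is compound 2 at 1.4 mL/min/g, also beyond the scatter. Compounds 2 and 3 sit within the scatter of each other. For the measured compounds named here, no pair of measured compounds differs in a single place, so no step can be read off between them.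

Compound 4, `O=S1(=O)CCCN1CCCSc1nc2cc(Cl)ccc2o1`, has not been measured. It differs from compound 1 as follows: a group of 7 heavy atoms (3 carbon, 1 nitrogen, 2 oxygen, 1 sulfur; one five-membered non-aromatic ring with 2 hetero atoms) in place of a group of 6 heavy atoms (4 carbon, 1 nitrogen, 1 oxygen; one five-membered non-aromatic ring with 1 hetero atom), on a saturated chain carbon, three bonds along the chain from a sulfur. Going by the values given here, nothing among the measured compounds bears directly on this change, so the expectation rests on compound 1 alone.

On that basis the step of a 1.4-fold lower number from compound 1 to compound 4 (0.14 log units; within the scatter) is expected to be small, in no firm direction, and within the usual scatter. Compound 4 is estimated at 3.5 mL/min/g in this assay, with a range from 1.5 mL/min/g to 8 mL/min/g.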

Compound 4, intrinsic clearance in a liver preparation (reported as CLH), per the amount of preparation that the assay uses: 4.7 mL/min/g
Compound 4: middle estimate off by 1.3-fold (0.13 log units), on the low side; the range from low to high includes it.
By their numbers in this assay, from the lowest: compounds 2 and 3 (each within the scatter of the next); then compounds 4 and 1 (each within the scatter of the next).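

In this assay, for the compounds shown here, the exchange of 2-oxopyrrolidin-1-yl for the five-membered non-aromatic ring with 2 hetero atoms, on a saturated chain carbon, three bonds along the chain from a sulfur, gives the first step that can be read at a single place: a 1.0-fold lower number from compound 1 to compound 4 (0.01 log units; within the scatter). The two compounds cannot be told apart on this read-out, so this one exchange, which adds a sulfur and a second double bond outside aromatic rings, leaves the clearance number within the scatter. No measurement is available to explain this result.

The lower numbers of compound 2 and compound 3 cannot be assigned to any single change, since each differs from compound 1 in more than one place. Still open, on these data alone, is whether the number at this position would respond to a different end group, such as a basic amine, a carboxylic acid or a six-membered piperidin-2-one ring, or to a shorter or longer chain carrying the same 2-oxopyrrolidin-1-yl group.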